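Acetylating the amino group of compound 2

A few compounds are considered here, and "the series" means these few. Any claim that something is new, unique, unknown or untested is made for them only; others in the source may bear on it.

Three compounds share one core. In an assay on isolated protein for inhibition of MAP kinase-activated protein kinase 2 (Homo sapiens), read by mobility shift assay, tested at 30 uM (on this read-out lower numbers stand for less inhibition and higher numbers for more inhibition at the one concentration tested (going by the name of the read-out)), compound 1 `Cc1cc2c(c(N)nn2C)c(=O)[nH]1` gives 29%, compound 2 `Cn1nc(N)c2c(=O)[nH]c(-c3ccccc3)cc21` gives 37%, and compound 3 `COc1cccc(-c2cc3c(c(N)nn3C)c(=O)[nH]2)c1` gives 47%. Compound 2 stands second highest of the three, with a number 8 percentage points higher from compound 1 to compound 2 (within the scatter) and a number 10 percentage points higher from compound 2 to compound 3 (within the scatter), both steps within the scatter. Compound 4 `CC(=O)Nc1nn(C)c2cc(-c3ccccc3)[nH]c(=O)c12` differs from compound 2 by acetyl in place of hydrogen on a nitrogen on an aromatic ring. Neither measured step touches this nitrogen; both are changes at other places and both small, so they give no direction for the acetyl change and no step beyond the scatter is expected. The expected step is a number 5 percentage points lower from compound 2 to compound 4 (within the scatter). For compound 4 in this assay the estimate is 32%, expected between 10% and 55%.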

Compound 4, a percentage reported as inhibition, at one concentration (the size of the read-out at that concentration, not a potency): 9%
Compound 4: middle estimate off by 23 percentage points, on the high side; the measured number lies below the stated range.
By their numbers in this assay, from the lowest: compound 4; then compounds 1, 2 and 3 (each within the scatter of the next, the first and the last beyond it).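

In this assay, for the compounds shown here, the change from amino to acetamido gives a number 28 percentage points lower from compound 2 to compound 4 (beyond the scatter), the only step in this set beyond the scatter. This nitrogen is therefore a place where the read-out responds to a change, which the phenyl and methoxy steps elsewhere on the shared core could not show. Nothing available gives a reason for this drop.

Going by these compounds, whether it belongs to acetyl alone or to any group on this nitrogen stays open; a methyl group or a longer acyl chain such as propionyl there would bear on that.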